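Swapping a Terminal Hydroxyl for a Methanesulfonamide

This account rests on a few compounds, and the source may have more. Where it says the series, first, only, none or still open, it means among the compounds named here.

Three compounds share one core. Compound 1 `CC(C)(C)OC(=O)NCCCCNC(=O)CN1CN(c2ccccc2)C2(CCN(C(=O)c3ccc(C(C)(C)C)cc3)CC2)C1=O` gives "not determined" (no result reported) in an assay on HEK293 cells for displacement of a labelled ligand from NPC1-like intracellular cholesterol transporter 1 (Homo sapiens) (on this read-out lower numbers stand for stronger inhibition and higher numbers for weaker inhibition), so no result is available for it. Compound 2 `CCOC(=O)C1CCN(C(=O)CN2CN(c3ccccc3)C3(CCN(C(=O)c4ccc(C(C)(C)C)cc4)CC3)C2=O)CC1` gives 3100 nM in this assay. Compound 3 `CC(C)(C)c1ccc(C(=O)N2CCC3(CC2)C(=O)N(CC(=O)NCCCCO)CN3c2ccccc2)cc1` gives 19200 nM in this assay, the higher of the two numbers available, and the step of a 6.2-fold higher number from compound 2 to compound 3 (0.79 log units; beyond the scatter) separates it from compound 2 by a clear margin.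

Compound 4 `CC(C)(C)c1ccc(C(=O)N2CCC3(CC2)C(=O)N(CC(=O)NCCCNS(C)(=O)=O)CN3c2ccccc2)cc1` differs from compound 3 in one place: methanesulfonamido in place of hydroxymethyl on a saturated chain carbon, three bonds along the chain from an amide-type nitrogen. Going by the values given here, the only measured step, a 6.2-fold higher number from compound 2 to compound 3 (0.79 log units; beyond the scatter), exchanges a whole amide substituent rather than the end of the chain kept here, so it does not speak directly to this change; it shows only that this part of the molecule can shift the number noticeably. With no closer comparison at hand, the safest expectation is a number near that of compound 3, with a wide range to either side.

Compound 4 is therefore estimated at 14000 nM in this assay, with a range from 4000 nM to 45000 nM. The step from compound 3 to compound 4 is expected to be a 1.4-fold lower number from compound 3 to compound 4 (0.14 log units; within the scatter), within the scatter.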

Compound 4, half-maximal inhibitory concentration: 10400 nM
Compound 4: the middle estimate sits 1.3-fold (0.13 log units) above what was measured; the range from low to high includes it.
By their numbers in this assay, from the lowest: compound 2; then compounds 4 and 3 (each within the scatter of the next).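

In this assay, the step with methanesulfonamido in place of hydroxymethyl on this saturated chain carbon is a 1.8-fold lower number from compound 3 to compound 4 (0.27 log units; within the scatter) and so stays within the usual scatter, which means these two chain ends cannot be told apart on this read-out. The larger change at the amide, (3-(methanesulfonamido)propyl)amino in place of 4-(ethoxycarbonyl)piperidin-1-yl, gives a 3.4-fold higher number from compound 2 to compound 4 (0.53 log units; beyond the scatter) and goes beyond the scatter, so compound 4, like compound 3, stands clearly apart from compound 2. Nothing in the available data offers a reason for either step.

On these data alone, whether a free amine or a carboxylic acid at the end of the chain would read differently from these two groups remains open. A longer chain carrying the methanesulfonamido group is also an open question.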